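The compounds below may be only part of what the source reports. "The series", "measured", "known", "first", "only" and "open" are said of these compounds alone.

Compound 1 `CCC(=O)Nc1ccc(S(=O)(=O)Oc2ccccc2C(C)C)cc1`, compound 2 `CC(C)C(=O)Nc1ccc(S(=O)(=O)Oc2ccccc2C(C)C)cc1` and compound 3 `CC(C)C(=O)Nc1ccc(S(=O)(=O)Oc2ccccc2I)cc1` share one core and differ only at the amide and at the aromatic substituent. In a functional assay on M21 cells (Homo sapiens) for antiproliferative activity, read by sulforhodamine B assay, with a stated time of 48 h (on this read-out higher numbers stand for weaker inhibition and lower numbers for stronger inhibition), compound 1 gives 11000 nM, compound 2 gives 11000 nM and compound 3 gives 13000 nM. The two steps between them, no change at the digits printed from compound 1 to compound 2 (within the scatter) and a 1.2-fold higher number from compound 2 to compound 3 (0.07 log units; within the scatter), both stay within the scatter, so compound 3 sits alongside the other two with no separation that can be read as real.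

Compound 4 `O=C(NCCCCl)Nc1ccc(S(=O)(=O)Oc2ccccc2I)cc1` is the next compound, not yet measured, and it differs from compound 3 by (3-chloropropyl)amino in place of isopropyl on a carbonyl carbon. Among the measured compounds shown here, no measured step touches this part of the molecule in a comparable way: the step from compound 1 to compound 2 only alters the chain bound to the carbonyl carbon by one methyl, and the step from compound 2 to compound 3 alters the aromatic substituent. For the measured compounds named here, neither moved the read-out beyond the scatter, and nothing among the measured compounds points in a direction for this larger change. Compound 4 is therefore expected to stay near its parent, with a 1.3-fold lower number from compound 3 to compound 4 (0.11 log units; within the scatter) as the estimated step. For compound 4 the estimate in this assay is 10000 nM, with a range from 3000 nM to 40000 nM.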

Compound 4, half-maximal inhibitory concentration: 4600 nM
Beside the measured number, compound 4's estimate is 2.2-fold (0.34 log units) above it; the range from low to high includes it.
By their numbers in this assay, from the lowest: compound 4; then compounds 1, 2 and 3 (each within the scatter of the next).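

In this assay, among the compounds shown here, the change on the carbonyl carbon, from isopropyl to (3-chloropropyl)amino (a 2.8-fold lower number from compound 3 to compound 4 (0.45 log units; beyond the scatter)), is the first step in this set to pass beyond the scatter, although it remains modest in size. The earlier change at this part of the molecule, a single added methyl on the chain bound to the carbonyl carbon (no change at the digits printed from compound 1 to compound 2 (within the scatter)), gave no readable shift, so this position is now seen to respond to a larger replacement, one that brings in a nitrogen, a chlorine and a hydrogen-bond donor together. Nothing available here accounts for the shift.

The compounds shown do not separate these three additions, so it stays open whether a plain propylamino group without the chlorine, a 3-bromopropylamino group or a longer chloroalkylamino chain would give a similar number. For the compounds shown here, it also stays open whether the same replacement would give a comparable step with isopropyl instead of iodo on the aromatic carbon, as all the evidence for it comes from the single pair of compound 3 and compound 4.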